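This account rests on a few compounds, and the source may have more. Where it says the series, first, only, none or still open, it means among the compounds named here.

Measured compounds and their values:
Compound 1, `O=c1[nH]c(=O)n([C@@H]2O[C@H](CO)[C@@H](O)[C@H]2O)cc1C#CC1CCCCC1`, gives 36800 nM in an ADME assay on MRC5 cells (Homo sapiens) for cytotoxicity, read by MTT assay; on this read-out higher numbers stand for lower toxicity in this test and lower numbers for higher toxicity in this test.
Compound 2, `CCCCC#Cc1cn([C@@H]2O[C@H](CO)[C@@H](O)[C@H]2O)c(=O)[nH]c1=O`, gives 11600 nM in this assay.

Among the compounds with values here, compound 2 holds the lower of the two numbers; its nearest neighbour is compound 1, and the one measured step, a 3.2-fold lower number from compound 1 to compound 2 (0.50 log units; beyond the scatter), separates them. Compound 3, `O=c1[nH]c(=O)n([C@@H]2O[C@H](CO)[C@@H](O)[C@H]2O)cc1C#CC(O)c1ccccc1`, is not yet measured. It differs from compound 2 in one place: hydroxy(phenyl)methyl in place of butyl on a triple-bonded carbon. Within the data shown here, only the step from compound 1 to compound 2 bears on this change, since it also exchanged the group on the same triple-bonded carbon, and there a ring-bearing group gave the higher number. Among the measured compounds shown here, the incoming group again carries a ring, so a modest rise in this assay is expected rather than a step beyond that, though the hydroxyl has no precedent here. Compound 3 is estimated at 20000 nM, within 8000 nM to 60000 nM, meaning an expected 1.7-fold higher number from compound 2 to compound 3 (0.24 log units; within the scatter).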

Compound 3, half-maximal cytotoxic concentration: 900 nM
Beside the measured number, compound 3's estimate is 22-fold (1.35 log units) above it, outside the stated range (below it).
By their numbers in this assay, from the lowest: compound 3; then compound 2; then compound 1.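

In this assay, the group on the triple-bonded carbon can shift the number much further than the first pair suggested: hydroxy(phenyl)methyl in place of butyl gives a 13-fold lower number from compound 2 to compound 3 (1.11 log units; beyond the scatter), and in place of cyclohexyl it gives a 41-fold lower number from compound 1 to compound 3 (1.61 log units; beyond the scatter). Carrying a ring is therefore no guide to a higher number at this position, since the ring-bearing compound 1 and compound 3 stand at opposite ends of the three values. No evidence is available to explain this drop.

The hydroxyl and the phenyl ring enter together as one group, so the compounds shown leave open whether one of them alone, or only the two combined, goes with the lower number. A plain phenyl group or a hydroxymethyl group on the same triple-bonded carbon would separate the two.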